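A few compounds are considered here, and "the series" means these few. Any claim that something is new, unique, unknown or untested is made for them only; others in the source may bear on it.

Going by the values given here, compound 1 `Cc1ccc(NC2=CC(=O)c3nc4n(c3C2=O)[C@H]2OC[C@@H](O)[C@H]2OC4)cc1` is the one compound here with an actual number: in a functional assay on MCF7 cells (Homo sapiens) for inhibition, read by sulforhodamine B assay (on this read-out higher numbers stand for weaker inhibition and lower numbers for stronger inhibition), compound 1 gives 1660 nM. Compound 2 `O=C1C(NC2CCCCC2)=CC(=O)c2c1nc1n2[C@H]2OC[C@@H](O)[C@H]2OC1` reaches only a limit, > 16000 nM, in this assay. Compound 3 `O=C1C(Nc2ccc(C(F)(F)F)cc2)=CC(=O)c2c1nc1n2[C@H]2OC[C@@H](O)[C@H]2OC1` likewise reaches only a limit, > 4000 nM. Among the compounds with values here, the single change measured between two compounds, a step that the two limits leave unreadable from compound 2 to compound 3, puts 4-(trifluoromethyl)phenyl in place of cyclohexyl on an amine nitrogen, and its size is hidden by the two limits. Within the data shown here, compound 4 `O=C1C=C(Nc2ccc(Br)cc2)C(=O)c2c1nc1n2[C@H]2OC[C@@H](O)[C@H]2OC1` differs from compound 1 by bromo in place of methyl on an aromatic carbon, a swap on the aromatic ring rather than at the amine nitrogen, so no measured step speaks to it directly. A change within the scatter is therefore expected, a 1.0-fold higher number from compound 1 to compound 4 (0.01 log units; within the scatter). Compound 4 is estimated at 1700 nM, between 600 nM and 5000 nM.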

Compound 4, half-maximal inhibitory concentration: 2580 nM
Estimate against measurement, compound 4: 1.5-fold (0.18 log units) below, and the stated range covers the measured number.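

In this assay, bromo in place of methyl on the aromatic carbon para to a large group gives a 1.6-fold higher number from compound 1 to compound 4 (0.19 log units; within the scatter), so the two groups cannot be told apart at this position. Going by these compounds alone, this is the first readable step, since the step between the two compounds held at limits cannot be read. No measurement shown here gives a cause for this step. As far as these compounds go, whether an amine, a carboxylic acid or a longer chain on this same aromatic carbon would also stay within the scatter remains open.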